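Carbamoyl to carboxy on the shared core

The source may report more compounds than this note shows. Statements on the series, on what has been measured and on what is new or still open speak of the compounds shown alone.

In a physicochemical assay for lipophilicity, read by HPLC, at pH 7.5 (on this read-out higher numbers stand for higher lipophilicity and lower numbers for lower lipophilicity), compound 1 (`CC[C@@H](Nc1c(C#N)c(-c2ccc(-c3cccc(C)c3F)cc2)nc2cnccc12)C(N)=O`) gives 3 while compound 2 (`CC[C@@H](Nc1c(C#N)c(-c2ccc(-c3ccc(Cl)cc3)cc2)nc2cnccc12)C(N)=O`) gives 3.1 and compound 3 (`CC[C@@H](Nc1c(C#N)c(-c2ccc(-c3ccccc3Cl)cc2)nc2cnccc12)C(N)=O`) gives 2.9 so the three numbers sit within the scatter of one another. Compound 1 therefore has no clear place of its own among them.

Compound 4 (`CC[C@@H](Nc1c(C#N)c(-c2ccc(-c3cccc(C)c3F)cc2)nc2cnccc12)C(=O)O`) has not yet been measured. The change from compound 1 is hydroxy in place of amino on a carbonyl carbon and it amounts to hydroxy in place of amino on a carbonyl carbon, which also reads as carbamoyl to carboxy.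

The measured steps offer little guidance. They are a number 0.10 log units higher from compound 1 to compound 2 (within the scatter) and a number 0.10 log units lower from compound 1 to compound 3 (within the scatter) and a number 0.20 log units lower from compound 2 to compound 3 (within the scatter) and each of them exchanges one substituted phenyl group for another on an aromatic carbon. Within the data shown here, none touches the carbonyl carbon, so the data hold no direct precedent for this change, and the small size of those steps sets no bound on it. A clear fall beyond the scatter is nevertheless expected, on the nature of the change alone. The expected move is a number 1.80 log units lower from compound 1 to compound 4 (beyond the scatter) and this remains an estimate with wide margins. For compound 4 the estimated value is 1.2 with an expected range from 0.4 to 2 on the same read-out.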

Compound 4, distribution coefficient: 2.1
Beside the measured number, compound 4's estimate is 0.90 log units below it, outside the stated range (above it).
By their numbers in this assay, from the lowest: compound 4; then compounds 3, 1 and 2 (each within the scatter of the next).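

In this assay, among these compounds, the carbonyl carbon proves to be a place where a single exchange moves the read-out clearly: carbamoyl to carboxy gives a number 0.90 log units lower from compound 1 to compound 4 (beyond the scatter) and so stands apart from the earlier steps, all of which exchanged one substituted phenyl group for another on an aromatic carbon and stayed within the scatter. The change is small by count, as one heavy atom replaces one, each group carries one hydrogen-bond donor, and neither carries a net charge, so these counts do not separate the two compounds although the read-out does. Nothing at hand accounts for the size of this step.

The compounds shown leave open whether hydroxy in place of amino would move the read-out by a similar amount with the 4-chlorophenyl group of compound 2 or the 2-chlorophenyl group of compound 3. They also leave open how the same carbonyl carbon would read with a methyl ester or a methylamino group, or how a longer chain in place of the 1-carboxypropyl group would read.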